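From Compound 3 to Compound 4: A Phenyl Group Exchange

The source may hold more compounds than are shown below. What is called first, only, known or untested is meant among the compounds shown, and "the series" means these compounds.

Of the compounds shown here, three sharing one core have been measured in an ADME assay on HUVEC cells (Homo sapiens) for cytotoxicity, read by MTT assay, with a stated time of 24 h (on this read-out lower numbers stand for higher toxicity in this test and higher numbers for lower toxicity in this test), so far. Compound 1 (`Clc1ccccc1/C=C/c1nnc(-c2ccc3c(c2)OCCO3)o1`) gives 368000 nM here, compound 2 (`COc1ccc(/C=C/c2nnc(-c3ccc4c(c3)OCCO4)o2)cc1`) gives 312000 nM here, and compound 3 (`Clc1ccc(/C=C/c2nnc(-c3ccc4c(c3)OCCO4)o2)cc1`) gives 312000 nM here. Compound 3 therefore stands level with compound 2 and within the scatter of compound 1.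

The next compound, compound 4 (`Cc1cccc(/C=C/c2nnc(-c3ccc4c(c3)OCCO4)o2)c1`), carries 3-methylphenyl in place of 4-chlorophenyl on a double-bonded chain carbon bound to a double-bonded chain carbon, a change counted as 3-methylphenyl in place of 4-chlorophenyl on a double-bonded chain carbon bound to a double-bonded chain carbon between the two structures. Going by the values given here, three measured steps bear on it. Exchanging 2-chlorophenyl for 4-chlorophenyl gave a 1.2-fold lower number from compound 1 to compound 3 (0.07 log units; within the scatter) in this series, exchanging 2-chlorophenyl for 4-methoxyphenyl gave a 1.2-fold lower number from compound 1 to compound 2 (0.07 log units; within the scatter) in this series, and chloro in place of methoxy on an aromatic carbon gave no change at the digits printed from compound 2 to compound 3 (within the scatter) in this series. Among the compounds with values here, all three lie within the scatter, although no compound with 3-methylphenyl has yet been measured. The expected step is a 1.0-fold higher number from compound 3 to compound 4 (0.02 log units; within the scatter) and thus none beyond the scatter in either direction. The estimate for compound 4 is 325000 nM with 200000 nM to 500000 nM as its expected range.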

Compound 4, half-maximal cytotoxic concentration: 201000 nM
For compound 4 the middle estimate is 1.6-fold (0.21 log units) above the measured one; the measured number falls inside the stated range.
By their numbers in this assay, from the lowest: compounds 4, 2, 3 and 1 (each within the scatter of the next).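

In this assay, 3-methylphenyl on a double-bonded chain carbon bound to a double-bonded chain carbon gives a 1.6-fold lower number from compound 3 to compound 4 (0.19 log units; within the scatter), a 1.6-fold lower number from compound 2 to compound 4 (0.19 log units; within the scatter) and a 1.8-fold lower number from compound 1 to compound 4 (0.26 log units; within the scatter), so this place has now carried four different substituted phenyl groups with no step beyond the scatter. Going by these compounds alone, the exchange also extends the series to a group with no chlorine and no methoxy: 4-chlorophenyl and 3-methylphenyl match in their counted heavy atoms, donors and acceptors, and they differ in that one carbon stands in for the chlorine and the substituent is named at a different ring number, yet the result is still no step that can be told from scatter. Nothing among the data shown accounts for the small differences seen in these numbers.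

The compounds shown leave open whether anything other than a phenyl ring with a small substituent at this place, such as an amine, a carboxylic acid or a longer chain on the ring, would move the number beyond the scatter in this assay. They also leave open whether a change elsewhere on the shared core would matter more than these exchanges have.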